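The source may hold more compounds than are shown below. What is called first, only, known or untested is meant among the compounds shown, and "the series" means these compounds.

Compound 1 `CCNC(=O)CCc1cccc2c1B(O)OC2` is a compound whose value in an ADME assay on WI-38 cells (Homo sapiens) for cytotoxicity, read by MTT assay, with a stated time of 72 h (a higher number here means a weaker inhibitor, a lower number a stronger inhibitor), is a limit of the assay, compound 1 giving > 100000 nM.
Compound 2 `O=C(CCc1cccc2c1B(O)OC2)Nc1nccs1` also sits at a limit of the assay, compound 2 giving > 100000 nM.
Compound 3 `O=C(CCc1cccc2c1B(O)OC2)Nc1ccc(Br)cc1` gives 42000 nM.

Compound 3 thus holds the only number shown; the other two values are limits (the limit of > 100000 nM in this assay, at which 2 of the 3 values shown sit). Compound 4 `O=C(CCc1cccc2c1B(O)OC2)Nc1ccc([N+](=O)[O-])cc1` differs from compound 3 by nitro in place of bromo on an aromatic carbon. The measured steps, an at least 2.3-fold lower number from compound 1 to compound 3 (0.37 log units; beyond the scatter) and an at least 2.3-fold lower number from compound 2 to compound 3 (0.37 log units; beyond the scatter), both swap the group on the amide-type nitrogen, not a group on an aromatic carbon, so none bears directly on this change. With no guide, a step within the scatter is expected in this assay. Compound 4 is therefore estimated at 50000 nM, between 15000 nM and 150000 nM, an expected step of a 1.2-fold higher number from compound 3 to compound 4 (0.08 log units; within the scatter).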

Compound 4, half-maximal inhibitory concentration: > 100000 nM
Compound 4: only a limit was reported; the forecaster's own chance of this, stated with the estimate: 35%; at least 2.0-fold (0.30 log units) between middle value and limit.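

In this assay, nitro in place of bromo on an aromatic carbon para to a large group gives an at least 2.3-fold higher number from compound 3 to compound 4 (0.37 log units; beyond the scatter). For the compounds shown here, the earlier steps changed only the group on the amide-type nitrogen, so this is the first sign that the group on the aromatic ring also moves the reading. Among the four compounds, only compound 3 with its bromo gives a number, and the others share one limit: the limit of > 100000 nM in this assay, at which 3 of the 4 values shown sit.

Going by these compounds, the true size of this step stays open, as compound 4 has only a limit. Also open, on these data alone, is what chloro, methyl or an amine would give on this carbon.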